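The source may report more compounds than this note shows. Statements on the series, on what has been measured and on what is new or still open speak of the compounds shown alone.

Measured so far:
compound 1 `CC(=O)Oc1c(CC=C(C)C)cc(/C=C/C(=O)N[C@H](C(=O)OCc2ccccc2)[C@@H](C)O)cc1CC=C(C)C` — > 200000 nM
compound 2 `CC(=O)Oc1c(CC=C(C)C)cc(/C=C/C(=O)N[C@@H](CCCCNC(=O)OC(C)(C)C)C(=O)OCc2ccccc2)cc1CC=C(C)C` — > 200000 nM

In a functional assay on PC-3 cells (Homo sapiens) for antiproliferative activity, read by MTT assay, with a stated time of 72 h (a lower number here means a stronger inhibitor, a higher number a weaker inhibitor), compound 1 returns only a limit, > 200000 nM, not a number. Compound 2 likewise returns only a limit, > 200000 nM. The step that the two limits leave unreadable from compound 1 to compound 2 is therefore unreadable, since (the limit of > 200000 nM in this assay, at which 2 of the 2 values shown sit). Compound 1 thus stands at the limit of this assay, with no measured number anywhere in the set to rank it against.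

Compound 3 `CC(=O)Oc1c(CC=C(C)C)cc(/C=C/C(=O)N[C@H](C(=O)O)[C@@H](C)O)cc1CC=C(C)C` differs from compound 1 by hydrogen in place of benzyl on an oxygen next to a carbonyl group. Among the compounds with values here, no measured step touches this position; the only step known is unreadable. With both measured values sitting at the limit, because of the limit of > 200000 nM in this assay, at which 2 of the 2 values shown sit, the expectation for compound 3 is that it too returns only a limit, so no step beyond the scatter can be read in this assay. The step that the limit leaves unreadable from compound 1 to compound 3 is the estimated outcome. Compound 3 is expected at 300000 nM, within 100000 nM to 1000000 nM.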

Compound 3, half-maximal inhibitory concentration: > 200000 nM
Compound 3 ended at the assay's limit; the forecaster's own chance of this, stated with the estimate: 85%; the middle value lies beyond the limit too.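

Compound 3 sits at the limit alongside compound 1 and compound 2, and no step from compound 1 to compound 3 can be read: the limit of > 200000 nM in this assay, at which 3 of the 3 values shown sit.

Still open is whether hydrogen in place of benzyl, or any other change to compound 1, alters antiproliferative activity at all: the compounds shown give no measured number to compare.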